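A few compounds are considered here, and "the series" means these few. Any claim that something is new, unique, unknown or untested is made for them only; others in the source may bear on it.

Measured compounds:
- compound 1, `CS(=O)(=O)C1CCc2c(c(-c3ccc(C(F)(F)F)c(SCCO)c3)nn2CCCN2CCC(N3CCCC3=O)CC2)C1`: 200 nM
- compound 2, `CS(=O)(=O)N1CCc2c(c(-c3ccc(C(F)(F)F)c(SCCNC(=O)c4ccccc4)c3)nn2CC(O)CN2CCC(N3CCCC3=O)CC2)C1`: 380 nM

Of the compounds shown here, two have been measured in an assay on isolated protein for inhibition of cathepsin S (Homo sapiens); on this read-out lower numbers stand for stronger inhibition and higher numbers for weaker inhibition. Compound 1 gives 200 nM and compound 2 gives 380 nM, the higher of the two numbers, but the gap between them lies within the usual scatter of this assay, so the two cannot be placed in order. Compound 3, `CN(C)c1ccc(C(=O)NCCSc2cc(-c3nn(CC(O)CN4CCC(N5CCCC5=O)CC4)c4c3CN(S(C)(=O)=O)CC4)ccc2C(F)(F)F)cc1`, has not yet been measured. It differs from compound 2 in one place: dimethylamino in place of hydrogen on an aromatic carbon. Going by the values given here, no step between measured compounds touches this position, so the size of the step cannot be read from the data; the closest comparison, compound 1 against compound 2, shows only a gap within the scatter for a much larger change at the same side chain. Compound 3 is therefore expected to stay close to compound 2, with the expected step of a 1.3-fold lower number from compound 2 to compound 3 (0.10 log units; within the scatter) small and in no firm direction. The estimate for compound 3 in this assay is 300 nM, with a range from 120 nM to 800 nM.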

Compound 3, half-maximal inhibitory concentration: 530 nM
Compound 3: middle estimate off by 1.8-fold (0.25 log units), on the low side; measured number inside the range.
By their numbers in this assay, from the lowest: compounds 1, 2 and 3 (each within the scatter of the next, the first and the last beyond it).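

The step from hydrogen to dimethylamino, which turns the phenyl of the benzamido group into 4-(dimethylamino)phenyl, gives a 1.4-fold higher number from compound 2 to compound 3 (0.14 log units; within the scatter) in this assay. Going by these compounds alone, this is the first step that touches this aromatic carbon, para to a large group, and it shows that a group of 3 heavy atoms can stand there without a difference that can be told from the scatter in this assay. Nothing at hand bears on why the two compounds read alike.

Since only hydrogen and dimethylamino are shown on this carbon, it remains open whether another group there, such as methoxy, a carboxylic acid or an amine on a longer chain, would give a step beyond the scatter. From the compounds shown here alone, it also remains open whether dimethylamino would give a similar reading with the benzamido group replaced, since compound 1 differs from compound 2 in more than one place and offers no such comparison.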